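This account rests on a few compounds, and the source may have more. Where it says the series, first, only, none or still open, it means among the compounds named here.

Working notes on the series around compound 1 `CC1CCN(C(=O)CN(C)C(=O)c2ccc(S(C)(=O)=O)c([N+](=O)[O-])c2)CC1`. In an assay on isolated protein for inhibition of thyroid hormone receptor beta (Homo sapiens), read by fluorescence polarization (a higher number here means a weaker inhibitor, a lower number a stronger inhibitor), compound 1 gives only a limit, > 60000 nM, and no number. Compound 2 `Cc1ccc(N2CCN(C(=O)C3CCN(C(=O)c4ccc(S(C)(=O)=O)c([N+](=O)[O-])c4)CC3)CC2)cc1`, which carries a larger amide-linked piece on the shared core, also returns only a limit in this assay, namely > 60000 nM. Compound 3 `CC1CCN(C(=O)CCNC(=O)c2ccc(S(C)(=O)=O)c([N+](=O)[O-])c2)CC1`, with a longer chain between the two carbonyls, likewise sits at a limit in this assay, > 60000 nM. Every value obtained so far is therefore a limit and nothing more: the limit of > 60000 nM in this assay, at which 3 of the 3 values shown sit. Among the compounds with values here, compound 1 can thus not be ordered against compound 2 or compound 3, and no step between measured compounds can be worked out.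

Compound 4 `CN(Cc1cccc(F)c1)C(=O)CN(C)C(=O)c1ccc(S(C)(=O)=O)c([N+](=O)[O-])c1` is the next member. It differs from compound 1 at one place, computed from the two structures: (3-fluorobenzyl)(methyl)amino in place of 4-methylpiperidin-1-yl on a carbonyl carbon

Within the data shown here, with all three measured members resting at the limit, there is no measured step from which a direction could be read. The step that the limit leaves unreadable from compound 1 to compound 4 is expected to be none beyond the scatter, because compound 1 sits at > 60000 nM and the series gives no sign of measurable binding. Compound 4 is expected to give about 80000 nM in this assay, within 20000 nM to 300000 nM, and most probably again only a limit.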

Compound 4, half-maximal inhibitory concentration: > 60000 nM
Compound 4: a limit, no number; the forecaster's own chance of this, stated with the estimate: 80%; the middle value does not contradict the limit.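

In this assay, within the data shown here, compound 4 gives > 60000 nM as a limit and no number, so no step from compound 1 to compound 4 can be read. The compounds shown leave open how (3-fluorobenzyl)(methyl)amino and 4-methylpiperidin-1-yl compare on the shared core, and whether any member of the series reaches a measurable value.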